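The compounds below may be only part of what the source reports. "The series", "measured", "known", "first", "only" and "open" are said of these compounds alone.

Among the measured compounds shown here, in a functional assay on QG-56 cells (Homo sapiens) for antiproliferative activity (on this read-out lower numbers stand for stronger inhibition and higher numbers for weaker inhibition), compound 1 `Cn1cncc1C(O)(c1ccc(C#N)cc1)c1cc2cc([N+](=O)[O-])cc(-c3ccc(F)cc3)c2o1` gives 158 nM and so holds the higher of the two numbers known so far, while compound 2 `COC(=O)c1cc(-c2cccc(OC)c2)c2oc(C(O)(c3ccc(C#N)cc3)c3cncn3C)cc2c1` gives 36.3 nM as the lower one. Compound 3 `Cc1cccc(-c2cc([N+](=O)[O-])cc3cc(C(O)(c4ccc(C#N)cc4)c4cncn4C)oc23)c1` carries 3-methylphenyl in place of 4-fluorophenyl on an aromatic carbon and is otherwise the same as compound 1. For the measured compounds named here, no two measured compounds differ in one place only, so nothing yet shows directly what this swap does. In this assay the expected step of a 1.6-fold lower number from compound 1 to compound 3 (0.20 log units; within the scatter) is small, towards a lower number, and possibly not beyond the scatter. For compound 3 the estimated value is 100 nM with an expected range of 35 nM to 280 nM for the coming measurement.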

Compound 3, half-maximal inhibitory concentration: 23.2 nM
Compound 3: middle estimate off by 4.3-fold (0.63 log units), on the high side, outside the stated range (below it).
By their numbers in this assay, from the lowest: compounds 3 and 2 (each within the scatter of the next); then compound 1.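

In this assay, among the compounds shown here, this is the first direct comparison at this position: 3-methylphenyl in place of 4-fluorophenyl on this aromatic carbon gives a 6.8-fold lower number from compound 1 to compound 3 (0.83 log units; beyond the scatter), with the rest of the molecule unchanged. The position is therefore sensitive to which substituted phenyl it carries, even though both groups have the same number of heavy atoms and one aromatic ring. Nothing measured here accounts for the step.

Going by these compounds, it remains open whether the methyl group, the loss of fluorine or the substituent's place on the ring drives the change; plain phenyl or 3-fluorophenyl at this position could separate these. On these data alone, how an amine on that ring would behave is also open.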